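Acylating the aryl amine: expected loss of cytotoxic potency

This account rests on a few compounds, and the source may have more. Where it says the series, first, only, none or still open, it means among the compounds named here.

Measured compounds:
compound 1 `COc1ccc(S(=O)(=O)N2CCc3cccc(NC(=O)N(C)c4ccccc4)c32)cc1`, > 10000 nM
compound 2 `COc1ccc(S(=O)(=O)N2CCc3cccc(NC(=O)Oc4ccccc4)c32)cc1`, > 10000 nM
compound 3 `COc1ccc(S(=O)(=O)N2CCc3cccc(N)c32)cc1`, 2800 nM

Going by the values given here, in a functional assay on KB cells (Homo sapiens) for cytotoxicity (a higher number here means a weaker inhibitor, a lower number a stronger inhibitor), compound 3 gives 2800 nM, the only number among the three; its amine is bare. For compound 1 the value > 10000 nM is a limit of the assay, not a number. For compound 2 the value > 10000 nM is likewise a limit. Compound 4 `COc1ccc(S(=O)(=O)N2CCc3cccc(NC(=O)c4ccc(F)cc4)c32)cc1` carries (4-fluorophenyl)carbonyl in place of hydrogen on a nitrogen on an aromatic ring. The two steps that bear on this are an at least 3.5-fold lower number from compound 1 to compound 3 (0.55 log units; beyond the scatter) and an at least 3.5-fold lower number from compound 2 to compound 3 (0.55 log units; beyond the scatter): capping the amine with either group pushed the number to the limit of > 10000 nM in this assay, at which 2 of the 3 values shown sit. A carbonyl group on the same nitrogen is expected to behave alike, so compound 4 is expected to show a 4.3-fold higher number from compound 3 to compound 4 (0.63 log units; beyond the scatter) and an estimated 12000 nM, in the range 5000 nM to 30000 nM.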

Compound 4, half-maximal inhibitory concentration: 93 nM
Compound 4: the middle estimate sits 130-fold (2.11 log units) above what was measured; measured number outside the range, below it.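

Capping this aromatic nitrogen does not in itself cost potency: with (4-fluorophenyl)carbonyl there is a 30-fold lower number from compound 3 to compound 4 (1.48 log units; beyond the scatter). Among these capped compounds, what sits on the carbonyl carbon makes the difference, with an at least 100-fold lower number from compound 2 to compound 4 (2.03 log units; beyond the scatter) and an at least 100-fold lower number from compound 1 to compound 4 (2.03 log units; beyond the scatter). Compounds 1 and 2 stay at a limit of the assay, not a number: the limit of > 10000 nM in this assay, at which 2 of the 4 values shown sit.

Still open, going by these compounds, is whether a plain phenylcarbonyl, without the fluorine, would give a number as low as that of compound 4. Also open, on these data alone, is how a small acetyl group or a pyridine-3-carbonyl group on the same nitrogen would compare.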